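Swapping the benzothiazole of compound 2 for a pyrazolylphenyl

The source may hold more compounds than are shown below. What is called first, only, known or untested is meant among the compounds shown, and "the series" means these compounds.

- Compound 1 `O=C(O)/C=C/c1ccc(/C(=C(\c2ccc(F)cc2Cl)C2CCC2)c2ccc3scnc3c2)cc1`: 3 nM
- Compound 2 `N#Cc1ccc(/C(=C(\c2ccc(/C=C/C(=O)O)cc2)c2ccc3scnc3c2)C2CCC2)c(Cl)c1`: 1.4 nM
- Compound 3 `N#Cc1cc(Cl)ccc1/C(=C(\c1ccc(/C=C/C(=O)O)cc1)c1ccc2scnc2c1)C1CCC1`: 0.9 nM

All three values come from a functional assay on MCF7 cells (Homo sapiens) for antiproliferative activity, read by CellTiter-Glo, with a stated time of 5 days; on this read-out lower numbers stand for stronger inhibition and higher numbers for weaker inhibition. Among them, compound 2 stands close to the low end of the numbers. The step of a 1.6-fold lower number from compound 2 to compound 3 (0.19 log units; within the scatter) does not separate the two compounds it joins, whereas a 2.1-fold lower number from compound 1 to compound 2 (0.33 log units; beyond the scatter) does, if only modestly.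

Compound 4 `N#Cc1ccc(/C(=C(\c2ccc(/C=C/C(=O)O)cc2)c2ccc(-c3cn[nH]c3)cc2)C2CCC2)c(Cl)c1` has not yet been measured. It differs from compound 2 in one place: 4-(1H-pyrazol-4-yl)phenyl in place of 1,3-benzothiazol-5-yl on a double-bonded chain carbon bound to an aromatic carbon and a double-bonded chain carbon.

Among the measured compounds shown here, no measured step touches that place, since all three measured compounds carry the 1,3-benzothiazol-5-yl group. The steps available, the two above and a 3.3-fold lower number from compound 1 to compound 3 (0.52 log units; beyond the scatter), all concern the other halogenated phenyl group. They are modest or smaller, so they show how far values have moved in this small set but give no direction for the new change. No step beyond the scatter is therefore expected, though the data leave this uncertain and the range is kept wide. The expected change is a 1.4-fold higher number from compound 2 to compound 4 (0.15 log units; within the scatter).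

For compound 4 the estimated value is 2 nM, with an expected range of 0.5 nM to 8 nM.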

Compound 4, half-maximal inhibitory concentration: 2.2 nM
Compound 4: the middle estimate sits 1.1-fold (0.04 log units) below what was measured; measured number inside the range.
By their numbers in this assay, from the lowest: compounds 3, 2, 4 and 1 (each within the scatter of the next, the first and the last beyond it).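

In this assay, among the compounds shown here, the first measured change on a double-bonded chain carbon bound to an aromatic carbon and a double-bonded chain carbon gives a 1.6-fold higher number from compound 2 to compound 4 (0.20 log units; within the scatter), so 4-(1H-pyrazol-4-yl)phenyl and 1,3-benzothiazol-5-yl are not separated on this read-out. The earlier steps shown here all concerned the other halogenated phenyl group, whereas this one shows that the position can take a different group with no shift beyond the scatter: the group that enters has 11 heavy atoms and 1 hydrogen-bond donor, and the one that leaves has 9 heavy atoms and 0 hydrogen-bond donors. Nothing at hand bears on why these two groups read alike.

On these data alone, the replacement is seen only alongside the 2-chloro-4-cyanophenyl group, so it remains open whether 4-(1H-pyrazol-4-yl)phenyl would read the same with the 4-chloro-2-cyanophenyl group of compound 3 or the 2-chloro-4-fluorophenyl group of compound 1. Also open, as far as these compounds go, is how this position would respond to a plain phenyl, or to an imidazole or a primary amine in place of the pyrazole.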